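The source may hold more compounds than are shown below. What is called first, only, known or untested is meant among the compounds shown, and "the series" means these compounds.

Of the compounds shown here, three have so far been tested in an ADME assay on HEp-2 cells (Homo sapiens) for cytotoxicity, read by MTT assay, with a stated time of 3 days; a lower number here means that less compound is tolerated, a higher number that more compound is tolerated. Compound 1 `CC[C@H](CCn1cncn1)c1ccccc1` gives 97.7 ug/mL. Compound 2 `CC[C@@H](CCn1cncn1)c1ccccc1` gives 89.9 ug/mL. These two share every atom and bond and differ only in how one stereocentre is drawn (the fact that compounds 1 and 2 differ only in the configuration as drawn), and the step of a 1.1-fold lower number from compound 1 to compound 2 (0.04 log units; within the scatter). Compound 3 `CC[C@H](CCn1cncn1)c1ccc(F)cc1` carries a fluoro on an aromatic carbon where compound 1 has hydrogen; in this assay compound 3 gives 103 ug/mL, and the step of a 1.1-fold higher number from compound 1 to compound 3 (0.02 log units; within the scatter). Compound 3 therefore sits alongside compound 1 and compound 2, all three within the scatter of one another.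

Compound 4 `CC[C@@H](CCn1cncn1)c1ccc(F)cc1` is the one still to be measured. Compared with compound 3, (the two compounds have the same atoms and bonds and differ only in configuration as drawn: 1 of 1 stereo elements differ; a stereocentre at a saturated chain carbon is drawn R in compound 3 and S in compound 4). Among the compounds with values here, the step that bears directly on this is the one from compound 1 to compound 2, where the same kind of change at the same stereocentre gave a 1.1-fold lower number from compound 1 to compound 2 (0.04 log units; within the scatter), a difference within the scatter. The fluoro step a 1.1-fold higher number from compound 1 to compound 3 (0.02 log units; within the scatter) also changed little. The expectation is therefore no change beyond the scatter, a 1.1-fold lower number from compound 3 to compound 4 (0.04 log units; within the scatter). For compound 4 the estimate is 95 ug/mL, with a range from 65 ug/mL to 140 ug/mL.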

Compound 4, half-maximal cytotoxic concentration: 90.3 ug/mL
For compound 4 the middle estimate is 1.1-fold (0.02 log units) above the measured one; the measured number falls inside the stated range.
By their numbers in this assay, from the lowest: compounds 2, 4, 1 and 3 (each within the scatter of the next).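

Reversing the stereocentre with the fluoro in place gives a 1.1-fold lower number from compound 3 to compound 4 (0.06 log units; within the scatter), the same outcome within the scatter as a 1.1-fold lower number from compound 1 to compound 2 (0.04 log units; within the scatter) without it, so in this assay the configuration drawn at this saturated chain carbon makes no measurable difference in either the fluoro or the non-fluoro pair. Fluoro in place of hydrogen on the aromatic carbon can now also be read in the second configuration, where it gives a 1.0-fold higher number from compound 2 to compound 4 (0.00 log units; within the scatter), and the two readings of this change agree: the same change on two cores in this assay, a 1.1-fold higher number (0.02 log units; within the scatter) from compound 1 to compound 3 and a 1.0-fold higher number (0.00 log units; within the scatter) from compound 2 to compound 4, 1.0-fold (0.02 log units) apart, within the scatter of two such steps. Each of these two changes has now been seen twice, and none of the four steps reaches beyond the scatter.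

From the compounds shown here alone, whether this insensitivity holds for larger or differently charged groups on the aromatic ring, such as a nitrile, an amine or a carboxylic acid, remains open. Going by these compounds, it is also open whether a longer chain at the stereocentre would leave the two configurations as close together as they are here.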